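Lengthening the alkyl chain of compound 2

The source may hold more compounds than are shown below. What is called first, only, known or untested is meant among the compounds shown, and "the series" means these compounds.

Two compounds have been measured in a functional assay on SW-620 cells (Homo sapiens) for cytotoxicity, read by MTT assay, with a stated time of 48 h; on this read-out lower numbers stand for stronger inhibition and higher numbers for weaker inhibition:

compound 1, `CCCCCCCCCCCCNC(=O)[C@@H](NC(=O)c1cccs1)[C@@H](C)O`, with 29200 nM
compound 2, `CCCCCCCCCCCCNC(=O)[C@@H](NC(=O)/C=C/c1ccccc1)[C@@H](C)O`, with 200000 nM

Within the data shown here, compound 2 carries the highest of the two numbers; its only neighbour is compound 1, and the sole measured step, a 6.8-fold higher number from compound 1 to compound 2 (0.84 log units; beyond the scatter), concerns the group on the carbonyl carbon and leaves the alkyl chain untouched. Compound 3, `CCCCCCCCCCCCCCCCCCNC(=O)[C@@H](NC(=O)/C=C/c1ccccc1)[C@@H](C)O`, differs from compound 2 by hexyl in place of hydrogen on a saturated chain carbon, ten or more bonds along the chain from an amide-type nitrogen. No measured step alters this chain, so nothing among the numbers shown speaks for either direction. Compound 3 is therefore expected to stay close to compound 2, with a step of no change at the digits printed from compound 2 to compound 3 (within the scatter) that lies within the scatter. The estimate for compound 3 is 200000 nM, with a range from 60000 nM to 500000 nM, and a real chance that the assay returns only a limit.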

Compound 3, half-maximal inhibitory concentration: 200000 nM
Compound 3: the middle estimate sits on the measured number at the digits printed; the measured number falls inside the stated range.
By their numbers in this assay, from the lowest: compound 1; then compounds 2 and 3 (each within the scatter of the next).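

Read in this assay the step gives no change at the digits printed from compound 2 to compound 3 (within the scatter) for hexyl in place of hydrogen on a saturated chain carbon, ten or more bonds along the chain from an amide-type nitrogen. Among these compounds, this is the first reading on the alkyl chain, which the earlier step left untouched, and with 2-phenylethenyl on the carbonyl carbon the added hexyl does not separate the two compounds. Nothing available here accounts for this result.

Going by these compounds, whether the same hexyl change would read alike with thiophen-2-yl on the carbonyl carbon, as in compound 1, remains open. Also open, on these data alone, is how a shorter chain, or an amine or a carboxylic acid in place of the hexyl, would read at this position.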